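This account rests on a few compounds, and the source may have more. Where it says the series, first, only, none or still open, it means among the compounds named here.

Working notes on the series.

Of the compounds shown here, three have been measured in a functional assay on the whole organism (strain Wistar Albino) for inhibition, with Rattus norvegicus as the target, read by paw edema, with a stated time of 4 h, at a dose of 20 mg/kg; on this read-out lower numbers stand for less inhibition and higher numbers for more inhibition at the one dose given (going by the name of the read-out). Compound 1 `COc1ccc(Cc2nnc3n2NC(c2ccc[nH]2)S3)cc1OC` gives 21.5% in this assay. Compound 2 `Cc1occc1-c1nnc2n1NC(c1ccc[nH]1)S2` gives 22.7% in this assay. Compound 3 `COc1ccc(Cc2nnc3n2NC(c2cccn2C)S3)cc1OC` gives 19.9% in this assay. The difference between compound 1 and compound 3 is methyl in place of hydrogen on an aromatic nitrogen, and the step that it made, a number 1.6 percentage points lower from compound 1 to compound 3 (within the scatter), is within the scatter, so the three measured numbers are not separated from one another. Compound 2 and compound 1 share no counted difference; the difference between the two cores is not broken down here.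

Compound 4 `Cc1occc1-c1nnc2n1NC(c1cccn1C)S2` is not yet measured. It differs from compound 2 by methyl in place of hydrogen on an aromatic nitrogen, the same change as from compound 1 to compound 3, at the same place on the pyrrole ring. For the measured compounds named here, with only one earlier instance, and that within the scatter, the expectation for compound 4 rests on compound 2 through 22.7% and on the small step of a number 1.6 percentage points lower from compound 1 to compound 3 (within the scatter) in this assay. The step expected from compound 2 to compound 4 is a number 1.7 percentage points lower from compound 2 to compound 4 (within the scatter), of the same small size as the earlier one. Compound 4 is therefore estimated at 21% in this assay, with a range of 12% to 30%.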

Compound 4, a percentage reported as inhibition, in the whole organism at one dose (the size of the read-out at that dose, not a potency): 22.4%
Compound 4: middle estimate off by 1.4 percentage points, on the low side; the measured number falls inside the stated range.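

In this assay, the change from 1H-pyrrol-2-yl to 1-methyl-1H-pyrrol-2-yl gives a number 0.3 percentage points lower from compound 2 to compound 4 (within the scatter). Set beside the earlier instance of the same change, the two steps do not differ: the same change on two cores in this assay, a number 1.6 percentage points lower (within the scatter) from compound 1 to compound 3 and a number 0.3 percentage points lower (within the scatter) from compound 2 to compound 4, 1.3 percentage points apart, within the scatter of two such steps

On these two cores, then, methyl in place of hydrogen on the aromatic nitrogen carries over as a step that cannot be told from the scatter, which shows no dependence on the core but does not show that the change is without consequence, since a dependence smaller than the scatter would go unseen and other cores, doses and times lie outside these data.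

The compounds shown leave open whether a larger group on that nitrogen, such as a longer chain or a benzyl group, would give a step beyond the scatter. They also leave open what an amine or a carboxylic acid in place of the methyl would do in this read-out.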